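The source may report more compounds than this note shows. Statements on the series, on what has been measured and on what is new or still open speak of the compounds shown alone.

Compound 1: `Clc1ccccc1-c1cc(-c2cnn(C3CCNCC3)c2)on1`; in an assay on a protein complex for positive allosteric modulation of Neuronal acetylcholine receptor; alpha4/beta2 (Homo sapiens) (a lower number here means a smaller maximal response, a higher number a larger maximal response), compound 1 gives 38%.
Compound 2: `Cc1cc(-c2cnn(C3CCNCC3)c2)on1`; in this assay compound 2 gives 19%.

Of these two numbers, compound 2 stands lowest; its nearest neighbour is compound 1, reached through the step of a number 19 percentage points lower from compound 1 to compound 2 (beyond the scatter), where methyl replaced 2-chlorophenyl on an aromatic carbon. The next compound, compound 3 `c1nn(C2CCNCC2)cc1-c1cc(C2CCCCC2)no1`, differs from compound 2 in one place: cyclohexyl in place of methyl on an aromatic carbon. Within the data shown here, the only measured step that bears on this change is a number 19 percentage points lower from compound 1 to compound 2 (beyond the scatter), in which removing 2-chlorophenyl in favour of methyl lowered the maximal response by a modest amount. Putting cyclohexyl in place of methyl at that same aromatic carbon goes the other way, toward a larger group again, so an upward step in this assay is expected, estimated as a number 14 percentage points higher from compound 2 to compound 3 (beyond the scatter). Compound 3 is accordingly expected to give about 33%, within a range of 18% to 50%.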

Compound 3, largest response reached (reported as efficacy), in percent of the reference or control that the assay uses: 16%
Compound 3: the middle estimate sits 17 percentage points above what was measured, outside the stated range (below it).
By their numbers in this assay, from the lowest: compounds 3 and 2 (each within the scatter of the next); then compound 1.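

In this assay, cyclohexyl in place of methyl on the aromatic carbon next to the ring nitrogen gives no difference that can be separated from the scatter: a number 3 percentage points lower from compound 2 to compound 3 (within the scatter). Cyclohexyl does not match 2-chlorophenyl at this position, with a number 22 percentage points lower from compound 1 to compound 3 (beyond the scatter), so a bigger group at this carbon does not by itself bring back the response of compound 1. Nothing measured here explains why compound 1 stands apart from the other two.

As far as these compounds go, it remains open whether the higher response of compound 1 depends on the aromatic ring or on its chlorine, a question that plain phenyl at this carbon would address. From the compounds shown here alone, how an amine or a carboxylic acid at this position would read in this assay also stays open.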